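Alkyne-substituent variation on the shared dichloro core

The source may hold more compounds than are shown below. What is called first, only, known or untested is meant among the compounds shown, and "the series" means these compounds.

Measured compounds:
- compound 1, `CC1(C#Cc2c(Cl)c3c(Cl)cc(C(N)=O)nc3n2[C@H]2CCCNC2)COC1`: 119 nM
- compound 2, `CC(O)C#Cc1c(Cl)c2c(Cl)cc(C(N)=O)nc2n1[C@H]1CCCNC1`: 147 nM
- compound 3, `COCCC#Cc1c(Cl)c2c(Cl)cc(C(N)=O)nc2n1[C@H]1CCCNC1`: 39 nM

All three were tested in a functional assay on KG-1 cells (Homo sapiens) for antiproliferative activity; a lower number here means that less compound is needed, a higher number that more compound is needed for the effect. Compound 2 gives the highest number of the three; its nearest neighbour is compound 1, with a 1.2-fold higher number from compound 1 to compound 2 (0.09 log units; within the scatter), so the two cannot be separated. Compound 3 sits clearly apart, with a 3.8-fold lower number from compound 2 to compound 3 (0.58 log units; beyond the scatter) and a 3.1-fold lower number from compound 1 to compound 3 (0.48 log units; beyond the scatter).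

The unmeasured compound 4, `CC(C)(O)C#Cc1c(Cl)c2c(Cl)cc(C(N)=O)nc2n1[C@H]1CCCNC1`, is derived from compound 2 by methyl in place of hydrogen on a saturated chain carbon bound to an oxygen on a saturated carbon, a saturated chain carbon and a triple-bonded carbon. Going by the values given here, none of the measured steps is this change; the closest comparisons are the swaps of one alkyne substituent for another, where the 3-methyloxetan-3-yl to 1-hydroxyethyl exchange gave a 1.2-fold higher number from compound 1 to compound 2 (0.09 log units; within the scatter) and only the move to 2-methoxyethyl brought a modest gain. Adding a methyl at the carbinol carbon is a smaller alteration than either of those, so in this assay a step within the scatter is expected, in no particular direction.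

Compound 4 is therefore estimated at 140 nM in this assay, with a range of 60 nM to 350 nM, which corresponds to an expected step of a 1.1-fold lower number from compound 2 to compound 4 (0.02 log units; within the scatter).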

Compound 4, half-maximal effective concentration: 302 nM
For compound 4 the middle estimate is 2.2-fold (0.33 log units) below the measured one, and the stated range covers the measured number.
By their numbers in this assay, from the lowest: compound 3; then compounds 1 and 2 (each within the scatter of the next); then compound 4.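

In this assay, methyl in place of hydrogen on the carbon bearing the hydroxyl gives a 2.1-fold higher number from compound 2 to compound 4 (0.31 log units; beyond the scatter), so this single added carbon moves the number beyond the scatter, whereas the exchange of 3-methyloxetan-3-yl for 1-hydroxyethyl did not. The 1-hydroxy-1-methylethyl group also separates compound 4 from the other two alkyne substituents, with a 2.5-fold higher number from compound 1 to compound 4 (0.40 log units; beyond the scatter) and a 7.7-fold higher number from compound 3 to compound 4 (0.89 log units; beyond the scatter), which leaves compound 4 with the highest number of the four and makes the gap to 2-methoxyethyl the widest in the set. Nothing available on these compounds accounts for the direction or size of the methyl step.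

The compounds shown leave open whether the hydroxyl or the carbon carrying it governs this trend, since neither 2-hydroxyethyl, which would place the hydroxyl further along the chain, nor 1-methoxy-1-methylethyl, which would cap it, appears among them. They also leave open whether a longer ether chain such as 3-methoxypropyl, or an amine such as 2-(dimethylamino)ethyl, would extend the lower number of compound 3 at 39 nM.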